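A few compounds are considered here, and "the series" means these few. Any claim that something is new, unique, unknown or untested is made for them only; others in the source may bear on it.

In a physicochemical assay for solubility, read by HPLC, in phosphate buffer, with a stated time of 4 h, at pH 7.4, tested at 10 mg/mL (a higher number here means a more soluble compound, a lower number a less soluble compound), three compounds have been measured so far. Compound 1 `Cc1cc(CCC#N)cc(C)c1Oc1cc(Nc2ccc(C#N)cc2)c(N)cc1C(=O)N(C)C` gives 1.08 ug/mL, compound 2 `Cc1cc(CCC#N)cc(C)c1Oc1cc(Nc2ccc(C#N)cc2)c(N)cc1C(=O)NC1CC1` gives 1.94 ug/mL, and compound 3 `CC(=O)OCc1cc(N)c(Nc2ccc(C#N)cc2)cc1Oc1c(C)cc(CCC#N)cc1C` gives 1.86 ug/mL. Compound 3 therefore lies within the scatter of both other compounds, and the three numbers do not separate. Compound 4 `COCc1cc(N)c(Nc2ccc(C#N)cc2)cc1Oc1c(C)cc(CCC#N)cc1C` differs from compound 3 in one place: methyl in place of acetyl on an oxygen on a saturated carbon. This is methyl in place of acetyl on an oxygen on a saturated carbon, or acetoxymethyl to methoxymethyl. For the measured compounds named here, no measured step makes this exact exchange. The nearest evidence is a 1.7-fold higher number from compound 1 to compound 3 (0.24 log units; within the scatter) and a 1.0-fold lower number from compound 2 to compound 3 (0.02 log units; within the scatter), both of which change the group on the same aromatic carbon and stay within the scatter. a 1.8-fold higher number from compound 1 to compound 2 (0.25 log units; within the scatter) also stays within it. On that indirect evidence, no change beyond the scatter is expected in this assay, and the direction cannot be called. The estimate means an expected 1.2-fold lower number from compound 3 to compound 4 (0.07 log units; within the scatter). For compound 4 the estimated value is 1.6 ug/mL, with an expected range of 0.7 ug/mL to 3.6 ug/mL.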

Compound 4, solubility: 0.66 ug/mL
Compound 4: the middle estimate sits 2.4-fold (0.38 log units) above what was measured; the measured number lies below the stated range.
By their numbers in this assay, from the lowest: compounds 4, 1, 3 and 2 (each within the scatter of the next, the first and the last beyond it).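

Methyl in place of acetyl on an oxygen on a saturated carbon gives a 2.8-fold lower number from compound 3 to compound 4 (0.45 log units; beyond the scatter) in this assay, so this group separates two compounds, which no step among the earlier compounds had done. The methoxymethyl group also falls beyond the scatter against the cyclopropylcarbamoyl group, with a 2.9-fold lower number from compound 2 to compound 4 (0.47 log units; beyond the scatter), but not against the dimethylcarbamoyl group, with a 1.6-fold lower number from compound 1 to compound 4 (0.21 log units; within the scatter), so the change at this aromatic carbon is not uniform in size. Nothing available explains the step from acetoxymethyl to methoxymethyl.

The compounds shown leave open whether a hydroxymethyl group or a longer chain such as ethoxymethyl at this carbon would give a number closer to that of compound 3 or compound 4. They also leave open how an aminomethyl group or a carboxylic acid there would read.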